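The source may report more compounds than this note shows. Statements on the series, on what has been measured and on what is new or still open speak of the compounds shown alone.

Working notes on the series. The shared core is carried by three measured compounds: compound 1 `CCc1cccc(Nc2nc3nonc3nc2O)c1`, compound 2 `CCCCc1ccc(Nc2nc3nonc3nc2O)cc1` and compound 3 `CCCCc1ccc(Nc2nc3nonc3nc2O)c(F)c1`. In an assay on mitochondria from L6 cells (Rattus norvegicus) for activation, with a stated time of 90 min (a higher number here means that more compound is needed for the effect, a lower number that less compound is needed), compound 1 gives 25200 nM, compound 2 gives 2100 nM and compound 3 gives 1100 nM. Compound 3 stands at the lowest of the three numbers in this assay, with compound 2 the nearest, within the scatter, and compound 1 the furthest, beyond the scatter. Among the compounds with values here, the one step between compounds differing in a single place is a 1.9-fold lower number from compound 2 to compound 3 (0.28 log units; within the scatter).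

Compound 4 `Oc1nc2nonc2nc1Nc1ccc(C(F)(F)F)cc1F` is not yet measured in this assay. From compound 3 it differs as follows: trifluoromethyl in place of butyl on an aromatic carbon. Within the data shown here, no measured step exchanges butyl for trifluoromethyl, so nothing in this assay bears directly on the change; the only step at hand, fluoro in place of hydrogen, lies within the scatter. Compound 4 is therefore expected near compound 3 in this assay, with a step of a 1.8-fold higher number from compound 3 to compound 4 (0.26 log units; within the scatter) that may run either way. The estimate for compound 4 is 2000 nM, between 500 nM and 8000 nM.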

Compound 4, half-maximal effective concentration: 2600 nM
The estimate for compound 4 lay 1.3-fold (0.11 log units) below the measured number; the range from low to high includes it.
By their numbers in this assay, from the lowest: compounds 3, 2 and 4 (each within the scatter of the next, the first and the last beyond it); then compound 1.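

In this assay, within the data shown here, trifluoromethyl in place of butyl on this aromatic carbon, para to a large group and meta to a fluoro group, gives a 2.4-fold higher number from compound 3 to compound 4 (0.37 log units; beyond the scatter), a modest change and the first step between compounds differing in one place that lies beyond the scatter. The two groups have the same count of heavy atoms, no ring and no hydrogen-bond donors or acceptors, so the number at this position can shift with those counts unchanged. Nothing measured on these compounds speaks to the origin of the step.

The compounds shown leave open whether trifluoromethyl gives the same step in the absence of the fluoro group. Also open, from the compounds shown here alone, is how a longer chain, an amine or a carboxylic acid on this carbon would compare with butyl.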